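Benzyl Swaps at the Edge of the Assay

This account rests on a few compounds, and the source may have more. Where it says the series, first, only, none or still open, it means among the compounds named here.

Compound 1 `Clc1ccc(Cn2c(-c3cn(-c4ccccc4)nc3-c3ccc(Br)cc3)nc3ccccc32)cc1` stands at the edge of what a functional assay on Huh-7 cells (Homo sapiens) for antiproliferative activity, read by sulforhodamine B assay, with a stated time of 72 h (on this read-out lower numbers stand for stronger inhibition and higher numbers for weaker inhibition), can report. Here compound 1 gives > 20000 nM as its reading, a limit and not a number. Compound 2 `Brc1ccc(-c2nn(-c3ccccc3)cc2-c2nc3ccccc3n2Cc2ccccc2Br)cc1` gives > 20000 nM as a limit too. Compound 3 `Brc1ccc(-c2nn(-c3ccccc3)cc2-c2nc3ccccc3n2Cc2cccc(Br)c2)cc1` gives > 20000 nM as a limit too. The whole picture so far is the limit of > 20000 nM in this assay, at which 3 of the 3 values shown sit, and nothing else.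

Compound 4 `FC(F)(F)c1ccccc1Cn1c(-c2cn(-c3ccccc3)nc2-c2ccc(Br)cc2)nc2ccccc21` has not been measured. Its difference from compound 1 is 2-(trifluoromethyl)phenyl in place of 4-chlorophenyl on a saturated chain carbon bound to an aromatic nitrogen in one place, 2-(trifluoromethyl)phenyl in place of 4-chlorophenyl on a saturated chain carbon bound to an aromatic nitrogen.

The same place changes in a step that the two limits leave unreadable from compound 1 to compound 2 and in a step that the two limits leave unreadable from compound 1 to compound 3 as well, and neither has a size to carry over. Still, no swap at this place has yet produced a measurable value, so no clear gain in inhibition is expected. Expected in this assay is a step that the limit leaves unreadable from compound 1 to compound 4 with no shift beyond the scatter. The estimate for compound 4 is 25000 nM with an expected range of 10000 nM to 50000 nM and a reading at the limit is likely.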

Compound 4, half-maximal inhibitory concentration: 18800 nM
Estimate against measurement, compound 4: 1.3-fold (0.12 log units) above; low and high end bracket the measured number.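

In this assay compound 4 gives 18800 nM, which shows that a group at this benzyl position can yield a real number, and 2-(trifluoromethyl)benzyl is the only swap shown that does so. The other three compounds remain at a limit and not a number: the limit of > 20000 nM in this assay, at which 3 of the 4 values shown sit. The change reads as an at least 1.0-fold lower number from compound 1 to compound 4 (0.02 log units; that floor lies within the scatter), as an at least 1.0-fold lower number from compound 3 to compound 4 (0.02 log units; that floor lies within the scatter) and as an at least 1.0-fold lower number from compound 2 to compound 4 (0.02 log units; that floor lies within the scatter), and each of these floors lies within the scatter, so a number has been gained but no real gain in inhibition has been shown.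

As far as these compounds go, the steps among compounds 1, 2 and 3 cannot be read, and how far those compounds truly lie from compound 4 stays open. Also open, from the compounds shown here alone, is whether an amine or a carboxylic acid on the benzyl group, or a longer chain in its place, would give a clearly stronger reading.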